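Removing one trifluoromethyl group from the urea end

The compounds below may be only part of what the source reports. "The series", "measured", "known", "first", "only" and "open" are said of these compounds alone.

Measured so far in a functional assay on SNB-75 cells (Homo sapiens) for inhibition, read by sulforhodamine B assay, with a stated time of 48 h, tested at 100 uM; on this read-out higher numbers stand for a weaker effect at the one concentration tested and lower numbers for a stronger effect:
- compound 1 `O=C(Nc1cccc(-n2cc(-c3ccncc3)c(-c3cc(O)cc(Cl)c3)n2)c1)Nc1ccc(Cl)c(C(F)(F)F)c1`: -41%
- compound 2 `O=C(Nc1cccc(-n2cc(-c3ccncc3)c(-c3cc(O)cc(Cl)c3)n2)c1)Nc1ccc(Cl)c(Cl)c1`: -15%
- compound 3 `COc1cc(Cl)cc(-c2nn(-c3cccc(NC(=O)Nc4cc(C(F)(F)F)cc(C(F)(F)F)c4)c3)cc2-c2ccncc2)c1`: -58%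

Compound 3 gives the lowest number of the three. Its nearest neighbour is compound 1 and the furthest is compound 2; both gaps from compound 3 lie beyond the scatter, so compound 3 stands as the strongest effect among the measured set.

Compound 4 `COc1cc(Cl)cc(-c2nn(-c3cccc(NC(=O)Nc4cccc(C(F)(F)F)c4)c3)cc2-c2ccncc2)c1` differs from compound 3 by hydrogen in place of trifluoromethyl on an aromatic carbon. For the measured compounds named here, only one measured step touches a trifluoromethyl on the urea end: a number 26 percentage points higher from compound 1 to compound 2 (beyond the scatter). That step moved the number toward a weaker effect when chloro replaced trifluoromethyl; dropping the group entirely is taken as a change of at least that kind. A step of similar size in the same direction is therefore expected: a number 23 percentage points higher from compound 3 to compound 4 (beyond the scatter). Going by the values given here, no measured pair shows the bare hydrogen at this position, so the range is kept wide. Compound 4 is estimated at -35%, between -60% and -5%.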

Compound 4, a percentage reported as activity, at one concentration (the size of the read-out at that concentration, not a potency): -17%
Compound 4: the middle estimate sits 18 percentage points below what was measured; the measured number falls inside the stated range.
By their numbers in this assay, from the lowest: compound 3; then compound 1; then compounds 4 and 2 (each within the scatter of the next).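

In this assay, hydrogen in place of trifluoromethyl on an aromatic carbon gives a number 41 percentage points higher from compound 3 to compound 4 (beyond the scatter), a large shift towards a weaker effect. The earlier step, a number 26 percentage points higher from compound 1 to compound 2 (beyond the scatter), showed only a chloro entering at a trifluoromethyl on the urea end; this one shows that the position also responds when the group leaves with no heavy atom entering, and that the trifluoromethyl kept in compound 4 does not hold the number of compound 3. No measurement at hand accounts for the size of this step.

As far as these compounds go, whether a methyl group or a nitrile in this place would keep the number near that of compound 3 remains open. Also open, from the compounds shown here alone, is whether the same change gives a step of this size with the hydroxy group of compound 1 in place of the methoxy group.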